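Bicyclic Sulfonate Nucleosides: From Ester to Benzoyl Urea

The source may report more compounds than this note shows. Statements on the series, on what has been measured and on what is new or still open speak of the compounds shown alone.

Compound 1 `CCOC(=O)CNC(=O)NC1=CS(=O)(=O)O[C@@]12[C@@H](CO[Si](C)(C)C(C)(C)C)O[C@@H](n1cc(C)c(=O)n(C)c1=O)[C@@H]2O[Si](C)(C)C(C)(C)C`: 5020 nM
Compound 2 `Cc1cn([C@@H]2O[C@@H]3COC4(O)CS(=O)(=O)O[C@@]34[C@H]2O)c(=O)[nH]c1=O`: 100000 nM

In a functional assay on CCRF-CEM cells (Homo sapiens) (on this read-out higher numbers stand for lower toxicity in this test and lower numbers for higher toxicity in this test), compound 1 gives 5020 nM, the lowest of the two numbers, while compound 2 gives 100000 nM, a gap that lies beyond the scatter. Among the measured compounds shown here, no single-point step between the measured compounds is available. Compound 3 `Cc1cn([C@@H]2O[C@H](CO[Si](C)(C)C(C)(C)C)[C@@]3(OS(=O)(=O)C=C3NC(=O)NC(=O)c3ccccc3)[C@H]2O[Si](C)(C)C(C)(C)C)c(=O)n(C)c1=O` is derived from compound 1 by the change (benzoyl in place of (ethoxycarbonyl)methyl on an amide-type nitrogen). With no measured comparison of this kind, the step of a 1.3-fold lower number from compound 1 to compound 3 (0.10 log units; within the scatter) is expected to be small, leaning toward a slightly lower number. For compound 3 the expected value is 4000 nM, within 1200 nM to 15000 nM.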

Compound 3, half-maximal cytotoxic concentration: 2290 nM
Beside the measured number, compound 3's estimate is 1.7-fold (0.24 log units) above it; the range from low to high includes it.
By their numbers in this assay, from the lowest: compound 3; then compound 1; then compound 2.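

In this assay, benzoyl in place of (ethoxycarbonyl)methyl on an amide-type nitrogen gives a 2.2-fold lower number from compound 1 to compound 3 (0.34 log units; beyond the scatter), so this position responds to the change, though only modestly. The ester is therefore not required to keep the number low, and an aromatic ring of carbon only is accepted here. Nothing at hand explains the step.

On these data alone, whether an amine or a carboxylic acid on that nitrogen would move the number further remains open. So does whether a longer chain would do so.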